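A few compounds are considered here, and "the series" means these few. Any claim that something is new, unique, unknown or untested is made for them only; others in the source may bear on it.

Measured compounds:
- compound 1, `CCCC(Nc1cncc(-c2ccc(O)c(OC)c2)n1)c1ccc(F)cc1`: in a functional assay on PC-3 cells (Homo sapiens) for cytotoxicity, read by MTT assay, with a stated time of 72 h (a lower number here means a stronger inhibitor, a higher number a weaker inhibitor), compound 1 gives "not determined" (no result reported)
- compound 2, `CCCC(Nc1cncc(-c2ccc(O)c(OC)c2)n1)c1cccc(OC)c1`: in this assay compound 2 gives 10000 nM

Within the data shown here, compound 2 holds the only number in this assay; compound 1 carries no result, so nothing can be ordered against it and compound 2 is neither strong nor weak by comparison, only weak in absolute terms. Among the measured compounds shown here, no step between measured compounds is available, so the series offers no precedent for how a change at this position moves the read-out.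

Compound 3, `CCCC(Nc1cncc(-c2ccc(O)c(OC)c2)n1)c1cccc(Cl)c1`, differs from compound 2 in one place: chloro in place of methoxy on an aromatic carbon. Without a measured step to lean on, the expectation for this change is a small shift of a 1.4-fold lower number from compound 2 to compound 3 (0.15 log units; within the scatter), not beyond the usual scatter, in no confident direction; a modest gain in potency is taken as slightly more likely than a loss, given how weak compound 2 already reads. Compound 3 is therefore estimated at 7000 nM in this assay, with a range of 2000 nM to 30000 nM.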

Compound 3, half-maximal inhibitory concentration: 1000 nM
Beside the measured number, compound 3's estimate is 7.0-fold (0.85 log units) above it, outside the stated range (below it).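

In this assay, among these compounds, the change from 3-methoxyphenyl to 3-chlorophenyl gives a 10-fold lower number from compound 2 to compound 3 (1.00 log units; beyond the scatter) and supplies the first step. It shows that, with the rest of the molecule held fixed, one substituent at this place on the aromatic ring can move the read-out beyond the usual scatter, and that chloro reads as the stronger of the two groups here. This exchange removes two heavy atoms, including a hydrogen-bond acceptor, and brings in one chlorine atom, but nothing available bears on which feature of the change accounts for the step.

A single pair cannot show whether the gain comes from losing methoxy or from gaining chloro, and a bromo, a trifluoromethyl, a nitrile or an amine at the same carbon would help separate these two readings. From the compounds shown here alone, it also remains open whether the step would hold with a longer chain in place of the existing one, or with a carboxylic acid in place of the phenol hydroxyl on the shared core.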